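From neopentyl to benzyl: how fast across the layer?

A few compounds are considered here, and "the series" means these few. Any claim that something is new, unique, unknown or untested is made for them only; others in the source may bear on it.

Among the measured compounds shown here, in an ADME assay on Caco-2 cells (Homo sapiens) for permeability, read by LC-MS, in the apical to basolateral direction, with a stated time of 60 min, at pH 6.5 (a lower number here means that the compound crosses the layer more slowly, a higher number that the compound crosses the layer faster), compound 3 `CC(C)(C)C[C@@H](O)C(=O)N1N=CC[C@H]1C(=O)NCc1cc(Cl)ccc1-n1cnnn1` gives 24 10^-6 cm/s and stands highest of the three numbers so far. Compound 1 `Cc1cccc([C@@H](O)C(=O)N2N=CC[C@H]2C(=O)NCc2cc(Cl)ccc2-n2cnnn2)c1` gives 9.7 10^-6 cm/s and compound 2 `O=C(NCc1cc(Cl)ccc1-n1cnnn1)[C@@H]1CC=NN1C(=O)[C@H](O)c1ccccc1F` gives 8.9 10^-6 cm/s with no difference beyond the scatter (a 1.1-fold lower number from compound 1 to compound 2 (0.04 log units; within the scatter)). Unmeasured compound 4 `O=C(NCc1cc(Cl)ccc1-n1cnnn1)[C@@H]1CC=NN1C(=O)[C@H](O)Cc1ccccc1` carries phenyl in place of tert-butyl on a saturated chain carbon, two bonds along the chain from a carbonyl carbon and an oxygen on a saturated carbon. Two measured steps come closest, each modest and each ending at neopentyl (a 2.5-fold higher number from compound 1 to compound 3 (0.39 log units; beyond the scatter) and a 2.7-fold higher number from compound 2 to compound 3 (0.43 log units; beyond the scatter)). Neither starts from benzyl, so they guide only loosely. A modest fall of similar size is expected (a 2.2-fold lower number from compound 3 to compound 4 (0.34 log units; beyond the scatter)). For compound 4 the estimate is 11 10^-6 cm/s (expected range 6 10^-6 cm/s to 22 10^-6 cm/s).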

Compound 4, apparent permeability: 11 10^-6 cm/s
Beside the measured number, compound 4's estimate shows no gap at the digits printed, and the stated range covers the measured number.
By their numbers in this assay, from the lowest: compounds 2, 1 and 4 (each within the scatter of the next); then compound 3.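

Swapping neopentyl for benzyl at this position gives a change beyond the scatter in this assay (a 2.2-fold lower number from compound 3 to compound 4 (0.34 log units; beyond the scatter)), so compound 3 keeps the highest number. Benzyl also reads like the two aryl groups, with both steps within the scatter (a 1.2-fold higher number from compound 2 to compound 4 (0.09 log units; within the scatter); a 1.1-fold higher number from compound 1 to compound 4 (0.05 log units; within the scatter)), so the three ring-bearing compounds now sit together and neopentyl alone stands apart. No measurement shown gives a reason for this difference.

Still open, from the compounds shown here alone, is how a group other than these would read here: an amine, a carboxylic acid or a longer chain might sit with compound 3, with the ring-bearing compounds, or elsewhere.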